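This account rests on a few compounds, and the source may have more. Where it says the series, first, only, none or still open, it means among the compounds named here.

Compound 1 `CCN(Cc1ccccc1)Cc1nc2ccccc2c(-c2ccccc2)c1C(=O)N(CC)CC`: 373 nM
Compound 2 `CCOC(=O)c1c(Cl)nc2ccccc2c1-c1ccccc1`: 3700 nM

In an assay on brain with Translocator protein (Rattus norvegicus) as the target (on this read-out lower numbers stand for stronger inhibition and higher numbers for weaker inhibition), compound 1 gives the lower of the two numbers, and compound 2 gives a number that lies beyond the usual scatter above it. Compound 3 `CCN(Cc1ccccc1)Cc1nc2ccccc2c(-c2ccccc2)c1C(=O)N(C)c1ccccc1` keeps the core of compound 1 and changes one group: methyl(phenyl)amino in place of diethylamino on a carbonyl carbon. Among the compounds with values here, no measured pair shows what such a change does here, so the expectation rests on compound 1 alone; a modest move toward weaker binding, at the edge of the scatter, is expected, a 1.5-fold higher number from compound 1 to compound 3 (0.17 log units; within the scatter). Compound 3 is therefore estimated at 550 nM, within 150 nM to 2000 nM.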

Compound 3, half-maximal inhibitory concentration: 1320 nM
For compound 3 the middle estimate is 2.4-fold (0.38 log units) below the measured one; measured number inside the range.
By their numbers in this assay, from the lowest: compound 1; then compound 3; then compound 2.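

In this assay, methyl(phenyl)amino in place of diethylamino on a carbonyl carbon gives a 3.5-fold higher number from compound 1 to compound 3 (0.55 log units; beyond the scatter), so the group at this position does affect the number. Here a group with a six-membered aromatic ring fares worse than one with no ring. Nothing shown explains why the number rises. From the compounds shown here alone, it remains open whether the aromatic ring or the loss of the ethyl groups matters more. Dimethylamino, or ethyl(phenyl)amino, on the same carbonyl carbon would help separate the two.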